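The source may report more compounds than this note shows. Statements on the series, on what has been measured and on what is new or still open speak of the compounds shown alone.

Measured in a functional assay on the whole organism (strain albino) with Rattus norvegicus as the target, in the maximal electroshock model, with a stated time of 1 h, at a dose of 30 mg/kg by the intraperitoneal route; on this read-out higher numbers stand for more inhibition at the one dose given (going by the name of the read-out) and lower numbers for less inhibition:
compound 1 `COc1cccc(C2SCC(=O)N2c2nnc(CNn3c(C)nc4ccc(Br)cc4c3=O)s2)c1`: 60%
compound 2 `Cc1nc2ccc(Br)cc2c(=O)n1NCc1nnc(N2C(=O)CSC2c2ccccc2)s1`: 60%
compound 3 `COc1ccc(C2SCC(=O)N2c2nnc(CNn3c(C)nc4ccccc4c3=O)s2)cc1`: 60%

Compound 3 stands level with compounds 1 and 2 in this assay; its values and theirs lie within the scatter of one another, so no order among the three can be read. Compound 4 `COc1ccc(C2SCC(=O)N2c2nnc(CNn3c(C)nc4ccc(Br)cc4c3=O)s2)cc1` differs from compound 3 by bromo in place of hydrogen on an aromatic carbon. Within the data shown here, no measured step covers this exact change. Among the measured compounds shown here, the one step known, no change at the digits printed from compound 1 to compound 2 (within the scatter), concerns the other aromatic ring and shows that a single substituent change there left the read-out flat. Compound 1, which carries the bromo group, and compound 3, which lacks it, give the same figure. Accordingly the step of no change at the digits printed from compound 3 to compound 4 (within the scatter) is expected to stay within the scatter. Compound 4 is estimated at 60%, ranging from 45% to 75%.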

Compound 4, a percentage reported as inhibition, in the whole organism at one dose (the size of the read-out at that dose, not a potency): 60%
Compound 4: the middle estimate sits on the measured number at the digits printed; the range from low to high includes it.
By their numbers in this assay, from the lowest: compounds 1, 2, 3 and 4 (each within the scatter of the next).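

Bromo in place of hydrogen on an aromatic carbon of the ring that is part of a fused or bridged system reads in this assay as no change at the digits printed from compound 3 to compound 4 (within the scatter), the first direct reading at this position. With bromo present, the other aromatic ring stays equally flat: methoxy in place of hydrogen gives no change at the digits printed from compound 2 to compound 4 (within the scatter), and 4-methoxyphenyl in place of 3-methoxyphenyl gives no change at the digits printed from compound 1 to compound 4 (within the scatter). Nothing on hand bears on why these changes leave the read-out flat.

On these data alone, whether an amine or a carboxylic acid at the bromo position would shift the read-out stays open. The same holds for a longer chain in place of methoxy.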